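The source may hold more compounds than are shown below. What is called first, only, known or untested is meant among the compounds shown, and "the series" means these compounds.

In a functional assay on U-251 cells (Homo sapiens) for cytotoxicity (on this read-out lower numbers stand for stronger inhibition of growth and higher numbers for weaker inhibition of growth), compound 2 `COc1ccc(C2=C(c3ccc(SC)cc3)CC3CCCN3C2=O)cc1Br` gives 800 nM, the higher of the two numbers, and compound 3 `COc1ccc(C2=C(c3ccc(SC)cc3)CC3CCCN3C2=O)cc1OC` gives 300 nM. Compound 1 `COc1ccc(C2=C(c3cc(OC)c(OC)c(OC)c3)CC3CCCN3C2=O)cc1O` is reported only as a limit, > 100000 nM. Compound 4 `CSc1ccc(C2=C(c3ccc(O)c(O)c3)C(=O)N3CCCC3C2)cc1` has not yet been measured. It differs from compound 2 as follows: 3,4-dihydroxyphenyl in place of 3-bromo-4-methoxyphenyl on a double-bonded ring carbon. For the measured compounds named here, the only measured step on this aryl group, a 2.7-fold lower number from compound 2 to compound 3 (0.43 log units; beyond the scatter), is modest and replaces bromo with methoxy. Going by the values given here, compound 1 differs from the others in both aryl groups, so it gives no step for this change. Here both substituents change at once, so a modest step towards a higher number is expected, with wide uncertainty. The estimated change is a 2.5-fold higher number from compound 2 to compound 4 (0.40 log units; beyond the scatter). For compound 4 the estimate is 2000 nM, with an expected range of 300 nM to 15000 nM.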

Compound 4, concentration for 50% growth inhibition: 30000 nM
Estimate against measurement, compound 4: 15-fold (1.18 log units) below, and the stated range ends below it.
By their numbers in this assay, from the lowest: compound 3; then compound 2; then compound 4. At a limit, above all of these: compound 1.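

For the compounds shown here, the change to 3,4-dihydroxyphenyl gives a 38-fold higher number from compound 2 to compound 4 (1.57 log units; beyond the scatter) in this assay, a large step, where the only earlier step on this aryl group, a 2.7-fold lower number from compound 2 to compound 3 (0.43 log units; beyond the scatter), was modest. Going by these compounds alone, with the 4-(methylsulfanyl)phenyl group held constant, this position alone can therefore shift growth inhibition much further than the earlier compounds showed. The series also holds one value that is a limit: the limit of > 100000 nM in this assay, at which 1 of the 4 values shown sits.

Both substituents change at once here, so the compounds shown do not separate the contributions of the two hydroxy groups. Going by these compounds, how one hydroxy group alone, an amine or a carboxylic acid would behave on this ring remains open.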